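The compounds below may be only part of what the source reports. "The series", "measured", "known", "first", "only" and "open" are said of these compounds alone.

Compound 3 `CC(C)c1onc(-c2c(Cl)cccc2Cl)c1COc1ccc(CCCC(=O)O)cc1` carries the highest number of the three compounds whose values are known in an assay on HEK-293T cells for activation of Bile acid receptor (Homo sapiens), read by a luciferase reporter, with a stated time of 14 h; on this read-out lower numbers stand for an effect already at smaller amounts and higher numbers for an effect only at larger amounts of compound: compound 3 gives 6000 nM. Compound 1 `CC(C)c1onc(-c2ccccc2Cl)c1COc1ccc(COc2ccc(CC(=O)O)cc2)cc1` gives 2500 nM in this assay, and compound 2 `CC(C)c1onc(-c2c(Cl)cccc2Cl)c1COc1ccc(CNc2ccc(CC(=O)O)cc2)cc1` gives 1600 nM in this assay. For the measured compounds named here, the one step that runs between two compounds differing in a single place is a 3.8-fold higher number from compound 2 to compound 3 (0.57 log units; beyond the scatter), a change of the acid-bearing group rather than of the aryl ring.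

Compound 4 `Cc1cccc(C)c1-c1noc(C(C)C)c1COc1ccc(CCCC(=O)O)cc1` differs from compound 3 only at the aryl ring attached to the shared core: 2,6-dimethylphenyl in place of 2,6-dichlorophenyl on an aromatic carbon. Going by the values given here, no measured step touches this part of the molecule. Compound 1 and compound 2 differ both in the chlorine count of that ring and in the linker, so their two values show nothing clean about the aryl ring alone. Among the compounds with values here, the only available step, from the acid side, is modest, and there is no ground here for expecting a change beyond the scatter in this assay for a swap of chlorine for methyl. Compound 4 is therefore expected to give 6000 nM in this assay, with a range from 2000 nM to 18000 nM, and the step of no change at the digits printed from compound 3 to compound 4 (within the scatter) is estimated as no more than the scatter of repeated runs.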

Compound 4, half-maximal effective concentration: 7700 nM
Compound 4: middle estimate off by 1.3-fold (0.11 log units), on the low side; the measured number falls inside the stated range.
By their numbers in this assay, from the lowest: compounds 2 and 1 (each within the scatter of the next); then compounds 3 and 4 (each within the scatter of the next).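

Swapping the ring on an aromatic carbon of the five-membered aromatic ring with 1 nitrogen and 1 oxygen gives the first measured step at this position in this assay: a 1.3-fold higher number from compound 3 to compound 4 (0.11 log units; within the scatter), with 2,6-dimethylphenyl in place of 2,6-dichlorophenyl. On the acid-bearing group shared by compound 3 and compound 4, this assay therefore does not separate the two rings, which match in heavy-atom count and differ in that two methyl groups stand where two chlorines stood, so the position tolerates this exchange without a change that can be told from the scatter. No measurement offered here speaks to why the two groups read alike.

As far as these compounds go, whether the same exchange would also read alike on the acid-bearing group of compound 2 remains open, since the 2,6-dimethylphenyl ring appears here on one acid-bearing group only. Also open, from the compounds shown here alone, is what other groups would give at this position, such as an unsubstituted phenyl, 2,6-difluorophenyl, 2,6-dimethoxyphenyl or a pyridine ring, as both rings compared here carry a pair of small substituents.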